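This account rests on a few compounds, and the source may have more. Where it says the series, first, only, none or still open, it means among the compounds named here.

Measured so far in a functional assay on HeLa cells (Homo sapiens) for inhibition, read by MTT assay, with a stated time of 72 h; a lower number here means a stronger inhibitor, a higher number a weaker inhibitor
- compound 1 `Cc1ccc(-c2nnc(SCCCN3CCN(c4nc5ccccc5o4)CC3)o2)cc1` gives 133000 nM
- compound 2 `Oc1ccc(-c2nnc(SCCCN3CCN(c4nc5ccccc5o4)CC3)o2)cc1` gives 99500 nM
- compound 3 `c1ccc(-c2nnc(SCCCN3CCN(c4nc5ccccc5o4)CC3)o2)cc1` gives 67000 nM

Compound 1 does not stand apart from the other two, as all three values lie within the scatter of one another. The steps are a 1.3-fold lower number from compound 1 to compound 2 (0.13 log units; within the scatter) and a 2.0-fold lower number from compound 1 to compound 3 (0.30 log units; within the scatter), and a 1.5-fold lower number from compound 2 to compound 3 (0.17 log units; within the scatter) completes the set.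

Compound 4 `Cc1ccc(-c2nnc(SCCCN3CCN(c4nc5ccccc5s4)CC3)o2)cc1` has not yet been measured. It keeps the core of compound 1 and carries a single change: 1,3-benzothiazol-2-yl in place of 1,3-benzoxazol-2-yl on an amine nitrogen in a ring.

Among the measured compounds shown here, none of the measured steps tests this replacement. All three change a group on an aromatic carbon elsewhere in the molecule, so they give only indirect guidance. They show that three compounds have not moved beyond the scatter in this assay, and even a 2.0-fold lower number from compound 1 to compound 3 (0.30 log units; within the scatter) stays inside it. No step beyond the scatter is therefore expected, and no direction is favoured. The expected step is a 1.2-fold lower number from compound 1 to compound 4 (0.08 log units; within the scatter) in this estimate. For compound 4 the estimated value is 110000 nM, with an expected range of 45000 nM to 260000 nM. For the measured compounds named here, the range is kept wide since this replacement has no measured precedent here.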

Compound 4, half-maximal inhibitory concentration: 179000 nM
Compound 4: middle estimate off by 1.6-fold (0.21 log units), on the low side; measured number inside the range.
By their numbers in this assay, from the lowest: compounds 3, 2, 1 and 4 (each within the scatter of the next, the first and the last beyond it).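

Working notes on the series: 1,3-benzothiazol-2-yl in place of 1,3-benzoxazol-2-yl is the first change on an amine nitrogen in a ring, as the earlier steps all changed a group on an aromatic carbon elsewhere in the molecule. In this assay, this replacement gives a 1.3-fold higher number from compound 1 to compound 4 (0.13 log units; within the scatter), so the read-out does not separate the two groups at this position. No supporting measurement accompanies this result, and the origin of the small step stays unaddressed.

The compounds shown leave open whether any group on this ring nitrogen can move the number beyond the scatter, for example a benzyl or an acetyl group in place of the two fused-ring groups compared here. Also open, from the compounds shown here alone, is whether the same replacement reads alike when hydroxy or hydrogen stands in place of methyl on the aromatic carbon, and whether an amine or a carboxylic acid at that aromatic carbon, or a longer chain to the sulfur, changes the picture.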